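This account rests on a few compounds, and the source may have more. Where it says the series, first, only, none or still open, it means among the compounds named here.

Measured so far in a functional assay on the whole organism for antagonist activity, with Mus musculus as the target; a lower number here means that less compound is needed, a higher number that more compound is needed for the effect:
Compound 1 `CC(C#CCn1ccnc1)N1CCCC1=O`: 45 mg/kg
Compound 2 `CC(=O)N(C)CC#CCN1CCCC1`: > 10 mg/kg, a limit
Compound 3 `COC(=O)N(C)C(C)C#CCn1cncc1C`: > 100 mg/kg, a limit

Among the compounds with values here, compound 1 is the only compound with a number. Compound 2 has only a limit, > 10 mg/kg, and no number. Compound 3 holds the only other limit.

Compound 4 `CN(C)C(=O)N(C)CC#CCN1CCCC1` carries dimethylamino in place of methyl on a carbonyl carbon, which reads as acetyl to dimethylcarbamoyl: dimethylamino in place of methyl on a carbonyl carbon. Within the data shown here, no measured pair shows this change. The expectation therefore leans on compound 1 at 45 mg/kg. The expected step, a step that the limit leaves unreadable from compound 2 to compound 4, is modest and towards more compound needed in this assay. For compound 4 the estimated value is 30 mg/kg, with an expected range of 8 mg/kg to 100 mg/kg.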

Compound 4, dose for half-maximal effect: > 10 mg/kg
Compound 4: no number, only a limit (the forecaster's own chance of this, stated with the estimate: 45%); the middle value is on the limit's open side.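

Compound 2 and compound 4 both carry only a limit in this assay, so the step between them cannot be read: the limit of > 10 mg/kg in this assay, at which 2 of the 4 values shown sit.

The compounds shown leave open whether dimethylamino in place of methyl on a carbonyl carbon changes the dose needed.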